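Replacing chloro with nitro on the ketone ring

The source may report more compounds than this note shows. Statements on the series, on what has been measured and on what is new or still open speak of the compounds shown alone.

Compound 1 `Cc1ccc(/C=C(/Sc2ccc(F)cc2)C(=O)c2ccc(Cl)cc2)s1` gives 25000 nM in a functional assay on DU-145 cells (Homo sapiens) for inhibition, read by trypan blue exclusion, with a stated time of 96 h; a higher number here means a weaker inhibitor of growth, a lower number a stronger inhibitor of growth.
Compound 2 `CN(C)c1ccc(/C=C(/SCc2ccc(Cl)cc2)C(=O)c2ccc([N+](=O)[O-])cc2)cc1` gives > 100000 nM in this assay, which is a limit of the assay and not a number.
Compound 3 `Cc1ccc(/C=C(/SCc2ccc(Cl)cc2)C(=O)c2ccc(Cl)cc2)s1` gives 50000 nM in this assay.

Among the two numbers measured, compound 3 has the highest; its nearest neighbour is compound 1, and the step of a 2.0-fold higher number from compound 1 to compound 3 (0.30 log units; within the scatter) lies within the scatter. Compound 4 `Cc1ccc(/C=C(/SCc2ccc(Cl)cc2)C(=O)c2ccc([N+](=O)[O-])cc2)s1` differs from compound 3 in one place: nitro in place of chloro on an aromatic carbon. Within the data shown here, no measured step covers this change directly; the only measured step, a 2.0-fold higher number from compound 1 to compound 3 (0.30 log units; within the scatter), concerns the group on the sulfur and was within the scatter. Compound 2 also carries nitro on the ketone ring, and in this assay compound 2 reaches only the limit (the limit of > 100000 nM in this assay, at which 1 of the 3 values shown sits), but it differs from compound 4 in another place as well, so what it shows is no more than a hint. Compound 4 is therefore expected to give 80000 nM, between 30000 nM and 200000 nM, an estimated step of a 1.6-fold higher number from compound 3 to compound 4 (0.20 log units; within the scatter) that is likely small, with a real chance that only a limit is reported.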

Compound 4, concentration for 50% growth inhibition: 25000 nM
The estimate for compound 4 lay 3.2-fold (0.51 log units) above the measured number, outside the stated range (below it).
By their numbers in this assay, from the lowest: compounds 1, 4 and 3 (each within the scatter of the next). At a limit, above all of these: compound 2.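

Going from 4-chlorophenyl to 4-nitrophenyl, with the rest of the molecule unchanged, gives a 2.0-fold lower number from compound 3 to compound 4 (0.30 log units; within the scatter), so in this assay this position takes either group without a difference that stands out from the scatter. Compound 2 carries the same nitro group, and its reading is a limit of the assay and not a number: the limit of > 100000 nM in this assay, at which 1 of the 4 values shown sits. Putting 5-methylthiophen-2-yl in place of 4-(dimethylamino)phenyl gives an at least 4.0-fold lower number from compound 2 to compound 4 (0.60 log units; beyond the scatter), so among these compounds it is that exchange, and not the nitro group, that moves the reading beyond the scatter.

From the compounds shown here alone, whether an amine or a carboxylic acid at this position would shift the number beyond the scatter remains open. Also open, going by these compounds, is whether nitro would behave the same way with 4-fluorophenyl on the sulfur.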